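From 5-hydroxypyridin-2-yl to 4-hydroxyphenyl in compound 3

The source may report more compounds than this note shows. Statements on the series, on what has been measured and on what is new or still open speak of the compounds shown alone.

Of the compounds shown here, two have been read so far in a physicochemical assay for lipophilicity, read by HPLC, at pH 7.4; a lower number here means a more polar compound, a higher number a more lipophilic compound. Compound 1 (`CCC/N=C1\S/C(=C\c2ccc(O)c(Cl)c2)C(=O)N1C1CCS(=O)(=O)CC1`) gives 2.6. Compound 2 (`CCC/N=C1\S/C(=C\c2ccc(O)cn2)C(=O)N1c1ccccc1C`) gives 3, the higher of the two numbers, with a gap beyond the usual scatter. Compound 3 (`CCC/N=C1\S/C(=C\c2ccc(O)cc2)C(=O)N1c1ccccc1C`) has not yet been measured. It differs from compound 2 in one place, carrying 4-hydroxyphenyl in place of 5-hydroxypyridin-2-yl on a double-bonded chain carbon bound to a double-bonded ring carbon. For the measured compounds named here, compounds 1 and 2 differ in more than one place, so no measured step speaks to this change, and the expectation rests on the structural change alone. A rise in this assay beyond the scatter is expected. The expected step is a number 0.60 log units higher from compound 2 to compound 3 (beyond the scatter). For compound 3 the estimated value is 3.6, with an expected range of 3.2 to 4.1.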

Compound 3, distribution coefficient: 3.5
The estimate for compound 3 lay 0.10 log units above the measured number; the measured number falls inside the stated range.
By their numbers in this assay, from the lowest: compound 1; then compound 2; then compound 3.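

In this assay, putting 4-hydroxyphenyl in place of 5-hydroxypyridin-2-yl on a double-bonded chain carbon bound to a double-bonded ring carbon gives a number 0.50 log units higher from compound 2 to compound 3 (beyond the scatter), so a change at this position alone now has a size beyond the scatter. The earlier pair differed in more than one place and could not isolate this position; here, an aromatic ring of carbon only replaces a six-membered aromatic ring with 1 hetero atom, and the rest of the structure stays the same. No measurement shown explains the size or direction of this step.

As far as these compounds go, one step at one position gives no trend, so it remains open whether the step would hold with the other groups on the shared core changed. From the compounds shown here alone, how this assay would respond to an amine or a carboxylic acid on the aromatic ring also remains open.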